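The compounds below may be only part of what the source reports. "The series", "measured", "known", "first", "only" and "open" are said of these compounds alone.

Measured so far:
- compound 1, `O=C(O)CNc1ccc2ccc(C(=O)c3ccc(F)c(O)c3)nc2c1`: 3%
- compound 2, `Nc1ccc2ccc(C(=O)c3ccc(F)c(O)c3)nc2c1`: 21%

Both were run in an assay for inhibition of 17-beta-hydroxysteroid dehydrogenase type 1 (Homo sapiens), read by HPLC, with a stated time of 10 min, tested at 1 uM; a lower number here means less inhibition, a higher number more inhibition at the concentration tested (going by the name of the read-out). Compound 2 gives the higher of the two numbers; the step from compound 1 to compound 2 is a number 18 percentage points higher from compound 1 to compound 2 (beyond the scatter), and it consists of hydrogen in place of carboxymethyl on a nitrogen on an aromatic ring. Compound 3, `O=C(c1ccc(F)c(O)c1)c1ccc2ccc(-c3nnn[nH]3)cc2n1`, has not yet been measured. It differs from compound 2 by 1H-tetrazol-5-yl in place of amino on an aromatic carbon. For the measured compounds named here, the only measured step touches the same place on the shared core: removing the carboxymethyl group there raised inhibition by a number 18 percentage points higher from compound 1 to compound 2 (beyond the scatter), so a larger group at that place, compound 1, gave the lower number. On that single comparison a group larger than amino is expected to lower inhibition again, though the entering group is of a different kind, so the comparison is loose. For compound 3 the estimate is 8% with a range of 0% to 22%, an expected step of a number 13 percentage points lower from compound 2 to compound 3 (beyond the scatter).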

Compound 3, a percentage reported as inhibition, at one concentration (the size of the read-out at that concentration, not a potency): "not active" (no number reported)
The entry for compound 3 holds no number; no gap can be computed for the estimate.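

For the compounds shown here, compound 3 is recorded as "not active" in this assay with no number, so no step from compound 2 to compound 3 can be read. No evidence shown bears on this result. The compounds shown leave open where compound 3 stands numerically against compound 1 and compound 2.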